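Replacing the benzyl group on the amine of compound 3

The source may report more compounds than this note shows. Statements on the series, on what has been measured and on what is new or still open speak of the compounds shown alone.

Three compounds sharing one core have so far been measured in an assay on CHO cells for displacement of a labelled ligand from 5-hydroxytryptamine receptor 1D (Homo sapiens); a lower number here means a stronger inhibitor, a higher number a weaker inhibitor:
compound 1 `c1ccc(CNC2CCN(CCCc3c[nH]c4ccc(-n5cnnc5)cc34)CC2)cc1` gives 4.6 nM;
compound 2 `CC(C)=CCN(C)C1CCN(CCCc2c[nH]c3ccc(-n4cnnc4)cc23)CC1` gives 0.5 nM;
compound 3 `c1ccc(CNCC2CCN(CCCc3c[nH]c4ccc(-n5cnnc5)cc34)CC2)cc1` gives 1.6 nM.

Compound 3 holds the second highest of these three numbers. It sits between the others: a 2.9-fold lower number from compound 1 to compound 3 (0.46 log units; beyond the scatter), while a 3.2-fold higher number from compound 2 to compound 3 (0.51 log units; beyond the scatter). The widest step seen is a 9.2-fold lower number from compound 1 to compound 2 (0.96 log units; beyond the scatter), where methyl(3-methylbut-2-en-1-yl)amino replaced benzylamino on a saturated ring carbon.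

Compound 4 `CC(=O)Nc1ccc([C@@H](C)NCC2CCN(CCCc3c[nH]c4ccc(-n5cnnc5)cc34)CC2)cc1` differs from compound 3 in one place: 1-(4-acetamidophenyl)ethyl in place of benzyl on an amine nitrogen. Going by the values given here, none of the measured steps bears directly on this change. The step of a 2.9-fold lower number from compound 1 to compound 3 (0.46 log units; beyond the scatter) put (benzylamino)methyl in place of benzylamino on a saturated ring carbon, and the step of a 9.2-fold lower number from compound 1 to compound 2 (0.96 log units; beyond the scatter) exchanged the whole amine substituent; in both compound 1 and compound 3 the benzyl group itself stays untouched. There is therefore no measured basis for expecting a step beyond the scatter in this assay in either direction, only the general observation that changes at this amine have so far moved the number by modest amounts. Compound 4 is expected to give about 1.6 nM, within a range of 0.4 nM to 6.5 nM. That estimate amounts to no change at the digits printed from compound 3 to compound 4 (within the scatter), essentially no change.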

Compound 4, half-maximal inhibitory concentration: 1.5 nM
For compound 4 the middle estimate is 1.1-fold (0.03 log units) above the measured one; low and high end bracket the measured number.
By their numbers in this assay, from the lowest: compound 2; then compounds 4 and 3 (each within the scatter of the next); then compound 1.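

In this assay, the group on the amine nitrogen of compound 3 grows with no readable effect: a 1.1-fold lower number from compound 3 to compound 4 (0.03 log units; within the scatter), with 1-(4-acetamidophenyl)ethyl in place of benzyl. Going by these compounds alone, the earlier steps exchanged the whole amine substituent or put a (benzylamino)methyl group in place of benzylamino, whereas this is the first step that alters only the group on this nitrogen, and it shows that the assay result can hold while that group gains an aromatic-ring acetamido substituent, a hydrogen-bond donor and acceptor, and a defined stereocentre. Nothing at hand explains why the number holds.

Compound 4 carries two additions at once, the extra methyl on the carbon attached to the nitrogen and the acetamido group, and the compounds shown cannot say what each does alone or whether their contributions offset each other. Going by these compounds, it also remains open whether the opposite configuration at the stereocentre, or a carboxylic acid or free amine in place of the acetamido group, would give a number within the scatter of compound 4.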